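From 2-chlorophenyl to 4-methoxyphenyl: expectation for compound 3

The source may report more compounds than this note shows. Statements on the series, on what has been measured and on what is new or still open speak of the compounds shown alone.

In a functional assay on A549 cells (Homo sapiens) for antiproliferative activity, read by MTT assay, with a stated time of 72 h (a higher number here means a weaker inhibitor, a lower number a stronger inhibitor), compound 1 `NC1=NC2(CCSCC2)N(OCCCOc2cccc(Cl)c2Cl)C(N)=N1` gives 1 nM, and compound 2 `NC1=NC2(CCSCC2)N(OCCCOc2ccccc2Cl)C(N)=N1` gives 80 nM, the higher of the two numbers. Compound 3 `COc1ccc(OCCCON2C(N)=NC(N)=NC23CCSCC3)cc1` has 4-methoxyphenyl in place of 2-chlorophenyl on an oxygen on a saturated carbon. Within the data shown here, only one measured step bears on this, the large 80-fold higher number from compound 1 to compound 2 (1.90 log units; beyond the scatter), with hydrogen in place of chloro on an aromatic carbon. It does not measure this exchange directly, but compound 3 also lacks the chloro lost in that step. The expected change is a 1.9-fold higher number from compound 2 to compound 3 (0.27 log units; within the scatter), a slightly higher number, not clearly beyond the scatter. For compound 3 the estimate is 150 nM, ranging from 30 nM to 800 nM.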

Compound 3, half-maximal inhibitory concentration: 240 nM
For compound 3 the middle estimate is 1.6-fold (0.20 log units) below the measured one; low and high end bracket the measured number.
By their numbers in this assay, from the lowest: compound 1; then compound 2; then compound 3.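

In this assay, 4-methoxyphenyl in place of 2-chlorophenyl gives a 3.0-fold higher number from compound 2 to compound 3 (0.48 log units; beyond the scatter), so the aryl group on this oxygen still moves the number once the 2,3-dichlorophenyl group is gone. Measured from the dichlorinated compound, 4-methoxyphenyl gives a 240-fold higher number from compound 1 to compound 3 (2.38 log units; beyond the scatter), and most of that span already lies in the step to 2-chlorophenyl. Nothing available explains either step.

The compounds shown do not separate the loss of chloro from the entry of methoxy. On these data alone, how an unsubstituted phenyl, a 4-chlorophenyl or a longer chain would read remains open.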